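The source may report more compounds than this note shows. Statements on the series, on what has been measured and on what is new or still open speak of the compounds shown alone.

- compound 1 `CC(=O)OC/C1=C/C[C@](C)(CCC=C(C)C)/C=C/[C@@H](OC(=O)C=C(C)C)[C@](C)(O)/C=C/C1=O`: 2950 nM
- compound 2 `CC(C)=CCC[C@]1(C)/C=C/[C@@H](OC(=O)C=C(C)C)[C@](C)(O)/C=C/C(=O)/C(C(=O)O)=C\C1`: > 10000 nM (a limit of the assay, not a number)
- compound 3 `CC(C)=CCC[C@]1(C)/C=C/[C@@H](OC(=O)C=C(C)C)[C@](C)(O)/C=C/C(=O)/C(CN2CCN(C)CC2)=C\C1`: 940 nM

These results come from a functional assay on A549 cells (Homo sapiens) for antiproliferative activity, read by MTT assay, with a stated time of 48 h; a lower number here means a stronger inhibitor, a higher number a weaker inhibitor. Compound 3, at 940 nM, holds the lower of the two actual numbers, and compound 1 is the nearest value. Compound 2 reached only a limit.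

The next compound to consider is compound 4 `COCOC/C1=C/C[C@](C)(CCC=C(C)C)/C=C/[C@@H](OC(=O)C=C(C)C)[C@](C)(O)/C=C/C1=O`. Its difference from compound 3 is methoxymethoxy in place of 4-methylpiperazin-1-yl on a saturated chain carbon bound to a double-bonded ring carbon. In words, methoxymethoxy stands in place of 4-methylpiperazin-1-yl on a saturated chain carbon bound to a double-bonded ring carbon.

Within the data shown here, two measured steps bear on this change. The closer one is a 3.1-fold lower number from compound 1 to compound 3 (0.50 log units; beyond the scatter), a modest step in which 4-methylpiperazin-1-yl replaced acetoxy at this same place. The other is an at least 10-fold lower number from compound 2 to compound 3 (1.02 log units; beyond the scatter), which is large but starts from carboxy and from a limit, so it says less about compound 4. Like compound 1, compound 4 has no 4-methylpiperazin-1-yl group, so much of the step seen with compound 1 is expected to be reversed in this assay. The expected change is a 2.7-fold higher number from compound 3 to compound 4 (0.42 log units; beyond the scatter), a modest move towards a weaker inhibitor. For compound 4 the estimated value is 2500 nM, with an expected range of 1000 nM to 6500 nM.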

Compound 4, half-maximal inhibitory concentration: 2980 nM
Estimate against measurement, compound 4: 1.2-fold (0.08 log units) below; measured number inside the range.
By their numbers in this assay, from the lowest: compound 3; then compounds 1 and 4 (each within the scatter of the next). At a limit, above all of these: compound 2.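

In this assay, the change from acetyl to methoxymethyl on an oxygen on a saturated carbon gives a 1.0-fold higher number from compound 1 to compound 4 (0.00 log units; within the scatter), so two different oxygen-linked groups at this place cannot be told apart, and the acetoxy of the first compound was not a special case. Exchanging 4-methylpiperazin-1-yl for methoxymethoxy gives a 3.2-fold higher number from compound 3 to compound 4 (0.50 log units; beyond the scatter), so the advantage of the piperazine-bearing compound now stands against a second oxygen-linked group as well as against acetoxy, with much the same size. Against the carboxy group the change reads an at least 3.3-fold lower number from compound 2 to compound 4 (0.52 log units; beyond the scatter), a step that rests on a limit of the assay and not on a number: the limit of > 10000 nM in this assay, at which 1 of the 4 values shown sits.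

The compounds shown hold only one amine at this place, so whether the lower number goes with the 4-methylpiperazin-1-yl ring itself or with amines in general stays open; a dimethylamino group or a morpholine ring there would bear on that. As far as these compounds go, how a free hydroxyl on this saturated chain carbon would read also remains open.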